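This account rests on a few compounds, and the source may have more. Where it says the series, first, only, none or still open, it means among the compounds named here.

Measured compounds:
compound 1, `CC(C)(C)n1ncc(OCc2nnc(-c3ccc(Cl)cc3)s2)c(Cl)c1=O`, 106000 nM;
compound 3, `CC(C)(C)n1ncc(OCc2nnc(-c3ccc(C(F)(F)F)cc3)o2)c(Cl)c1=O`, 33800 nM;
compound 2, `CC(C)(C)n1ncc(OCc2nnc(-c3cc(F)c(Cl)c([N+](=O)[O-])c3Cl)o2)c(Cl)c1=O`, a limit of > 299000 nM.

All three were tested in a functional assay on the whole organism for inhibition, with Mythimna separata as the target, with a stated time of 5 days; a higher number here means that more compound is needed for the effect, a lower number that less compound is needed. Among the two numbers that are not limits, compound 1 stands highest; its nearest neighbour is compound 3, whose number is lower by a margin that lies beyond the usual scatter. Compound 2 gives only a limit, (the limit of > 299000 nM in this assay, at which 1 of the 3 values shown sits), and so no number can be set beside it. No pair among these three differs in just one place, so no measured step is available to guide the next change.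

Compound 4, `Cc1cccc(-c2nnc(COc3cnn(C(C)(C)C)c(=O)c3Cl)s2)c1`, is not yet measured. It differs from compound 1 by 3-methylphenyl in place of 4-chlorophenyl on an aromatic carbon. For the measured compounds named here, nothing among the measured compounds bears a methyl group on that aromatic ring, so the size and direction of the step are taken as open. Compound 4 is expected to sit close to compound 1, with a step of a 1.2-fold higher number from compound 1 to compound 4 (0.09 log units; within the scatter) that is not expected to pass beyond the scatter. For compound 4 the estimate is therefore 130000 nM, within a range of 40000 nM to 400000 nM, and a limit rather than a number remains a real possibility.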

Compound 4, half-maximal effective concentration: > 299000 nM
Compound 4: no number, only a limit (the forecaster's own chance of this, stated with the estimate: 25%); middle value at least 2.3-fold (0.36 log units) from the limit.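

In this assay, for the compounds shown here, 3-methylphenyl in place of 4-chlorophenyl gives the first measured step at this position of the core of compound 1, an at least 2.8-fold higher number from compound 1 to compound 4 (0.45 log units; beyond the scatter), and this step lies beyond the usual scatter. The leaving and entering groups have the same number of heavy atoms and the same kind of ring, and neither carries a hydrogen-bond donor or acceptor, so these counts alone do not account for the difference in outcome. Compound 4 gives only a limit, not a number, and compound 2 gives the same limit: the limit of > 299000 nM in this assay, at which 2 of the 4 values shown sit.

Going by these compounds, the true size of the step therefore remains unknown, and the change alters both the substituent and where it sits on the phenyl ring, so the two contributions cannot be told apart. Whether 4-methylphenyl or 3-chlorophenyl would stay near compound 1 is open, as is whether 3-methylphenyl would give a number on the core of compound 3, which differs from compound 1 in more than one place.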